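From Bromo to Trifluoromethyl on the Aromatic Ring

A few compounds are considered here, and "the series" means these few. Any claim that something is new, unique, unknown or untested is made for them only; others in the source may bear on it.

Of the compounds shown here, three sharing one core have been measured in a functional assay (muscle tissue) with Cavia porcellus as the target (a higher number here means that more compound is needed for the effect, a lower number that less compound is needed), and they differ only in one group on the aromatic ring. Compound 1 `COC(=O)C1=C(C)N=C(C)/C(=C(\O)OC)C1c1cccc(OC)c1`, which carries methoxy, gives 191 nM. Compound 2 `COC(=O)C1=C(C)N=C(C)/C(=C(\O)OC)C1c1cccc(N)c1`, which carries amino, gives 2000 nM. Compound 3 `COC(=O)C1=C(C)N=C(C)/C(=C(\O)OC)C1c1cccc(Br)c1`, which carries bromo, gives 1.29 nM, the lowest number of the three.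

The unmeasured compound 4 `COC(=O)C1=C(C)N=C(C)/C(=C(\O)OC)C1c1cccc(C(F)(F)F)c1` has trifluoromethyl in place of bromo on an aromatic carbon. All three measured steps concern this same place. Amino in place of methoxy gives a 10-fold higher number from compound 1 to compound 2 (1.02 log units; beyond the scatter), bromo in place of methoxy gives a 150-fold lower number from compound 1 to compound 3 (2.17 log units; beyond the scatter), and bromo in place of amino gives a 1600-fold lower number from compound 2 to compound 3 (3.19 log units; beyond the scatter). These large steps show that this assay can respond strongly to a change here, but none of them involves trifluoromethyl, so the size of the next step remains uncertain.

Compound 3 already holds the lowest number, at 1.29 nM, so a moderate rise is expected, smaller than the measured steps. The expected change is a 6.2-fold higher number from compound 3 to compound 4 (0.79 log units; beyond the scatter). Compound 4 is estimated at 8 nM, with an expected range from 1.5 nM to 60 nM.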

Compound 4, half-maximal effective concentration: 74.1 nM
Compound 4: middle estimate off by 9.3-fold (0.97 log units), on the low side; measured number outside the range, above it.
By their numbers in this assay, from the lowest: compound 3; then compound 4; then compound 1; then compound 2.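

In this assay the change of bromo to trifluoromethyl gives a 57-fold higher number from compound 3 to compound 4 (1.76 log units; beyond the scatter) and so is a large step in its own right, even though both groups have 0 hydrogen-bond donors, 0 hydrogen-bond acceptors and no net charge. The position therefore separates groups that these counts do not tell apart, and the very low number of compound 3 does not carry over to trifluoromethyl. Against the other two groups, trifluoromethyl gives a 27-fold lower number from compound 2 to compound 4 (1.43 log units; beyond the scatter) and, in a modest step, a 2.6-fold lower number from compound 1 to compound 4 (0.41 log units; beyond the scatter). Compound 4 thus falls between compound 3 and compound 1, which leaves bromo well apart from the other three groups. The data shown offer nothing that explains the gap between bromo and trifluoromethyl.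

Going by these compounds, whether chloro or iodo at this place would give a number close to that of compound 3 or close to that of compound 4 remains open, and so does where a nitrile or a carboxylic acid would fall in this order. On these data alone, it is also open whether the same order of groups would hold on another carbon of the aromatic ring.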